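This account rests on a few compounds, and the source may have more. Where it says the series, first, only, none or still open, it means among the compounds named here.

In a functional assay on MIA PaCa-2 cells (Homo sapiens) for antiproliferative activity, read by sulforhodamine B assay, with a stated time of 48 h (a lower number here means a stronger inhibitor, a higher number a weaker inhibitor), compound 1 `COc1ccc(C(=O)/C=C\Nc2ccc(-c3nc4cc(OC)c(OC)c(OC)c4s3)cc2C)cc1[N+](=O)[O-]` gives 23400 nM and compound 2 `COc1cc(C(=O)/C=C\Nc2ccc(-c3nc4cc(OC)c(OC)c(OC)c4s3)cc2C)c(Br)c(OC)c1OC` gives 24300 nM. These two values lie within the scatter of each other, so compound 2 stands level with compound 1, even though the two compounds differ in the groups on the same ring. Compound 3 `COc1cc(C(=O)/C=C\Nc2ccc(-c3nc4cc(OC)c(OC)c(OC)c4s3)cc2C)cc(OC)c1OC` departs from compound 2 by a single change, hydrogen in place of bromo on an aromatic carbon. For the measured compounds named here, no measured pair shows this change alone, so nothing in the data fixes its size in this assay. A modest move toward a lower number, meaning a stronger inhibitor, is expected, though one that stays within the scatter would be no surprise. The expected move is a 2.4-fold lower number from compound 2 to compound 3 (0.39 log units; beyond the scatter). For compound 3 the estimated value is 10000 nM, with an expected range of 2500 nM to 35000 nM.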

Compound 3, half-maximal inhibitory concentration: 22800 nM
The estimate for compound 3 lay 2.3-fold (0.36 log units) below the measured number; the measured number falls inside the stated range.
By their numbers in this assay, from the lowest: compounds 3, 1 and 2 (each within the scatter of the next).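

In this assay, hydrogen in place of bromo on this aromatic carbon, ortho to a large group, gives a 1.1-fold lower number from compound 2 to compound 3 (0.03 log units; within the scatter) and so shows bromo and hydrogen standing level at this position. The 3,4,5-trimethoxyphenyl in place of 4-methoxy-3-nitrophenyl on a carbonyl carbon gives a 1.0-fold lower number from compound 1 to compound 3 (0.01 log units; within the scatter), which places all three compounds level and means that none of these groups on this ring separates them. Nothing available offers an explanation for this level result. The compounds shown leave open whether any group on this ring can move the number beyond the scatter. Whether an amine or a carboxylic acid on this aromatic carbon would also stand level with hydrogen and bromo remains an open question.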